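A few compounds are considered here, and "the series" means these few. Any claim that something is new, unique, unknown or untested is made for them only; others in the source may bear on it.

Measured compounds:
compound 1 `COc1ccc(C(=O)C(CC(=O)c2ccc(Cl)cc2)c2cn(-c3ccc(Cl)cc3)nc2-c2ccc(C)cc2)cc1`: in a functional assay on the whole organism (strain Wistar albino) for inhibition, with Rattus norvegicus as the target, read by paw edema, with stated times of 1 h and 2 h, at a dose of 0.32 mmol/kg by the intraperitoneal route (on this read-out lower numbers stand for less inhibition and higher numbers for more inhibition at the one dose given (going by the name of the read-out)), compound 1 gives 16.1%
compound 2 `Cc1ccc(-c2nn(-c3ccc(S(N)(=O)=O)cc3)cc2C(CC(=O)c2ccc(Cl)cc2)C(=O)c2ccc(F)cc2)cc1`: in this assay compound 2 gives 53.5%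

Compound 2 stands highest of the two numbers in this assay; the nearest is compound 1, lower by a margin beyond the scatter. Compound 3 `COc1ccc(C(=O)C(CC(=O)c2ccc(Cl)cc2)c2cn(-c3ccc(S(N)(=O)=O)cc3)nc2-c2ccc(C)cc2)cc1` is not yet measured. It differs from compound 2 by methoxy in place of fluoro on an aromatic carbon. Among the measured compounds shown here, no step between measured compounds covers this change alone; compound 1 and compound 2 differ in more than one place, so their two values show only that compound 2 lies higher. The expected step in this assay is a number 7.5 percentage points lower from compound 2 to compound 3 (within the scatter), small and not clearly beyond the scatter. Compound 3 is estimated at 46%, range 30% to 62%.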

Compound 3, a percentage reported as inhibition, in the whole organism at one dose (the size of the read-out at that dose, not a potency): 53.8%
Beside the measured number, compound 3's estimate is 7.8 percentage points below it, within the range that was stated.
By their numbers in this assay, from the lowest: compound 1; then compounds 2 and 3 (each within the scatter of the next).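

In this assay, 4-fluorophenyl to 4-methoxyphenyl on the carbonyl gives a number 0.3 percentage points higher from compound 2 to compound 3 (within the scatter), so this position takes either group without a change beyond the scatter. Among the compounds shown here, compound 3 also gives the first single-place reading of the sulfamoyl group: sulfamoyl in place of chloro gives a number 37.7 percentage points higher from compound 1 to compound 3 (beyond the scatter), a large step set against the small one at the carbonyl-bearing aryl ring. No measurement here bears on the reason for either step. Still open, on these data alone, is whether an amine or a carboxylic acid at the fluoro and methoxy position would read the same. As far as these compounds go, whether the sulfamoyl step holds with fluoro in place of methoxy also stays open.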